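The source may report more compounds than this note shows. Statements on the series, on what has been measured and on what is new or still open speak of the compounds shown alone.

In an assay on HEK293 cells for inhibition of acid ceramidase (Homo sapiens), with a stated time of 10 min (on this read-out higher numbers stand for weaker inhibition and lower numbers for stronger inhibition), compound 1 `O=C(NCCCCc1ccccc1)n1c(=O)oc2ccccc21` gives 64 nM. Compound 2 `O=C(NCCCCCc1ccccc1)n1c(=O)oc2ccccc21` gives 54 nM in this assay, and compound 3 `O=C(NCCCCc1ccc(F)cc1)n1c(=O)oc2ccccc21` gives 75 nM. Compound 3 thus carries the highest of the three numbers, yet a 1.2-fold higher number from compound 1 to compound 3 (0.07 log units; within the scatter) and a 1.4-fold higher number from compound 2 to compound 3 (0.14 log units; within the scatter) both lie inside the scatter, so no order among the three is secure. Compound 4 `O=C(NCCCCCCc1ccccc1)n1c(=O)oc2ccccc21` remains to be measured; it differs from compound 3 by phenethyl in place of 4-fluorophenyl on a saturated chain carbon, four bonds along the chain from an amide-type nitrogen. For the measured compounds named here, two measured steps bear on this change: a 1.2-fold higher number from compound 1 to compound 3 (0.07 log units; within the scatter) covers the fluoro, and a 1.2-fold lower number from compound 1 to compound 2 (0.07 log units; within the scatter) covers one added chain carbon. Both were small, so the further chain carbon is expected to give at most a modest step in this assay, probably toward a lower number. For compound 4 the expected value is 50 nM (range 25 nM to 100 nM), an expected step of a 1.5-fold lower number from compound 3 to compound 4 (0.18 log units; within the scatter).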

Compound 4, half-maximal inhibitory concentration: 51 nM
Estimate against measurement, compound 4: 1.0-fold (0.01 log units) below; low and high end bracket the measured number.
By their numbers in this assay, from the lowest: compounds 4, 2, 1 and 3 (each within the scatter of the next).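

In this assay, phenethyl in place of 4-fluorophenyl gives a 1.5-fold lower number from compound 3 to compound 4 (0.17 log units; within the scatter), benzyl in place of phenyl gives a 1.1-fold lower number from compound 2 to compound 4 (0.02 log units; within the scatter), and phenethyl in place of phenyl gives a 1.3-fold lower number from compound 1 to compound 4 (0.10 log units; within the scatter). Across these chain lengths no step leaves the scatter, so the series shows no secure dependence on chain length at this position. No measurement here accounts for this flat response.

From the compounds shown here alone, whether a longer chain than that of compound 4 would hold this range remains open. So does the effect of an amine or a carboxylic acid on the chain.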